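The source may hold more compounds than are shown below. What is called first, only, known or untested is meant among the compounds shown, and "the series" means these compounds.

Measured compounds in an ADME assay on L02 cells (Homo sapiens) for antiproliferative activity, read by MTT assay, with a stated time of 48 h; on this read-out lower numbers stand for stronger inhibition and higher numbers for weaker inhibition:
compound 1 `CCc1ccccc1-n1nncc1CN1C(=O)C2(C(C#N)=C(N)Oc3c(N)cc4nc5ccccc5nc4c32)c2ccccc21` — compound 1 gives 22900 nM
compound 2 `N#CC1=C(N)Oc2c(N)cc3nc4ccccc4nc3c2C12C(=O)N(Cc1cnnn1-c1ccc(F)cc1)c1ccccc12` — compound 2 reaches only a limit, > 50000 nM
compound 3 `N#CC1=C(N)Oc2c(N)cc3nc4ccccc4nc3c2C12C(=O)N(Cc1cnnn1-c1cccc(C(F)(F)F)c1)c1ccccc12` — compound 3 gives 38100 nM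

Compound 3 holds the highest of the two numbers in this assay; its nearest neighbour is compound 1, and the gap between them is within the scatter. The third value, that of compound 2, is a limit (the limit of > 50000 nM in this assay, at which 1 of the 3 values shown sits).

Compound 4 `COc1ccccc1-n1nncc1CN1C(=O)C2(C(C#N)=C(N)Oc3c(N)cc4nc5ccccc5nc4c32)c2ccccc21` is not yet measured. It differs from compound 3 in one place: 2-methoxyphenyl in place of 3-(trifluoromethyl)phenyl on an aromatic nitrogen.

All three measured steps concern the same aromatic nitrogen. an at least 2.1-fold higher number from compound 1 to compound 2 (0.33 log units; beyond the scatter). a 1.7-fold higher number from compound 1 to compound 3 (0.22 log units; within the scatter). an at least 1.3-fold lower number from compound 2 to compound 3 (0.11 log units; that floor lies within the scatter). Swapping the group on this nitrogen has so far moved the numbers in this assay only modestly, and the lone step beyond the scatter ran toward the limit.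

Compound 4 is therefore expected to land close to compound 3, with a 1.4-fold lower number from compound 3 to compound 4 (0.15 log units; within the scatter), most likely a number slightly lower and near that of compound 1, which gives 22900 nM. Compound 4 is estimated at 27000 nM, in the range 11000 nM to 60000 nM.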

Compound 4, half-maximal inhibitory concentration: > 50000 nM
Compound 4: a limit, no number; the forecaster's own chance of this, stated with the estimate: 25%; middle value at least 1.8-fold (0.26 log units) away from the limit.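

Compound 4 reaches only a limit in this assay, and it is the second compound in the series to do so: the limit of > 50000 nM in this assay, at which 2 of the 4 values shown sit.

The change from ethyl to methoxy on an aromatic carbon gives an at least 2.1-fold higher number from compound 1 to compound 4 (0.33 log units; beyond the scatter), so 2-ethylphenyl and 2-methoxyphenyl are not interchangeable on this nitrogen, even though both groups carry their substituent on the same ring carbon. The step to compound 3 is smaller, an at least 1.3-fold higher number from compound 3 to compound 4 (0.11 log units; that floor lies within the scatter), and the step between the two limits, compound 2 and compound 4, cannot be read.

From the compounds shown here alone, it remains open whether the measured number of compound 1 is specific to ethyl. A longer chain such as propyl, or an amine, on that same aromatic carbon would test this.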